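Swapping the fluorophenyl group of compound 2

The compounds below may be only part of what the source reports. "The series", "measured", "known", "first", "only" and "open" are said of these compounds alone.

Compound 1 `CC(C)[C@H](NC(=O)COc1cccc2ccccc12)C(=O)N[C@@H](CC(=O)O)C(=O)COc1ccc(OC(F)(F)F)cc1`: 29100 nM
Compound 2 `CC(C)[C@H](NC(=O)COc1cccc2ccccc12)C(=O)N[C@@H](CC(=O)O)C(=O)COc1ccc(F)cc1`: > 100000 nM

These values come from a functional assay on Jurkat cells (Homo sapiens); on this read-out lower numbers stand for stronger inhibition and higher numbers for weaker inhibition. Compound 2 gives > 100000 nM, which is a limit of the assay and not a number. Compound 3 `CC(C)[C@H](NC(=O)COc1cccc2ccccc12)C(=O)N[C@@H](CC(=O)O)C(=O)COc1c(F)cccc1F` differs from compound 2 in one place: 2,6-difluorophenyl in place of 4-fluorophenyl on an oxygen on a saturated carbon. Within the data shown here, the only measured guide is an at least 3.4-fold higher number from compound 1 to compound 2 (0.53 log units; beyond the scatter), which shows that a change on this aromatic group can move the read-out beyond the scatter. A step towards lower numbers is therefore expected in this assay, of uncertain size. The expected step is an at least 4.0-fold lower number from compound 2 to compound 3 (0.60 log units; beyond the scatter). For compound 3 the estimate is 25000 nM, with an expected range from 3000 nM to 100000 nM.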

Compound 3, half-maximal inhibitory concentration: 2040 nM
Compound 3: the middle estimate sits 12-fold (1.09 log units) above what was measured; measured number outside the range, below it.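

In this assay, among these compounds, the earlier compounds showed only that this aromatic group matters, whereas 2,6-difluorophenyl on this oxygen gives an at least 49-fold lower number from compound 2 to compound 3 (1.69 log units; beyond the scatter) and also a 14-fold lower number from compound 1 to compound 3 (1.15 log units; beyond the scatter). The ring that enters therefore does far better than both rings measured before it, including 4-(trifluoromethoxy)phenyl. Compound 2 stands at a limit of the assay, not at a number, so its step is only a lower bound: the limit of > 100000 nM in this assay, at which 1 of the 3 values shown sits.

Still open, on these data alone, is whether chlorine atoms or methyl groups in place of the two fluorines of 2,6-difluorophenyl would give a similar number. An amine on this ring is also untested among the compounds shown here.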